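Series notes: replacing 4-chlorocyclohexyl with cycloheptyl

The source may hold more compounds than are shown below. What is called first, only, known or untested is meant among the compounds shown, and "the series" means these compounds.

Measured in an ADME assay for protein binding, using equilibrium dialysis, at pH 7.4, tested at 2 uM; on this read-out higher numbers stand for a larger free fraction and lower numbers for a smaller free fraction:
- compound 1 `CC(C)N(c1cc(C#CC(C)(C)C)sc1C(=O)O)C(=O)[C@H]1CC[C@H](CF)CC1`: 0.18
- compound 2 `CC(C)N(c1cc(C#CC(C)(C)C)sc1C(=O)O)C(=O)[C@H]1CC[C@H](Cl)CC1`: 0.14

In this assay, among the compounds with values here, compound 2 gives 0.14, within the scatter of the only other measured compound. Compound 3 `CC(C)N(C(=O)C1CCCCCC1)c1cc(C#CC(C)(C)C)sc1C(=O)O` carries cycloheptyl in place of 4-chlorocyclohexyl on a carbonyl carbon. Within the data shown here, the one measured step, a 1.3-fold lower number from compound 1 to compound 2 (0.11 log units; within the scatter), exchanges chloro and fluoromethyl on a saturated ring carbon. Among the measured compounds shown here, it bears only loosely, as no measured compound carries cycloheptyl. A change within the scatter is expected in this assay, leaning slightly lower. The expected step is a 1.2-fold lower number from compound 2 to compound 3 (0.07 log units; within the scatter). For compound 3 the estimate is 0.12, with an expected range of 0.06 to 0.22.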

Compound 3, unbound fraction: 0.11
Compound 3: middle estimate off by 1.1-fold (0.04 log units), on the high side; measured number inside the range.
By their numbers in this assay, from the lowest: compounds 3, 2 and 1 (each within the scatter of the next).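

At this carbonyl carbon, in this assay, the seven-membered carbon ring of cycloheptyl stays within the scatter of both six-membered rings, replacing 4-chlorocyclohexyl (a 1.3-fold lower number from compound 2 to compound 3 (0.10 log units; within the scatter)) and 4-(fluoromethyl)cyclohexyl (a 1.6-fold lower number from compound 1 to compound 3 (0.21 log units; within the scatter)). Across these three compounds, the free fraction therefore does not depend on keeping the chlorine, the fluoromethyl group or the defined stereocentres of 4-chlorocyclohexyl. Nothing available explains this result. Still open, on these data alone, is whether an amine or a carboxylic acid on this ring, or an open alkyl chain in its place, would give a step beyond the scatter.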